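Switching a fluoro for a chloro on the benzyl ring

The compounds below may be only part of what the source reports. "The series", "measured", "known", "first", "only" and "open" are said of these compounds alone.

Of the compounds shown here, three sharing one core have been tested in an ADME assay on cells (Mus musculus, strain BALB/c) for cytotoxicity, read by MTT assay, with a stated time of 24 h; on this read-out lower numbers stand for higher toxicity in this test and higher numbers for lower toxicity in this test. Compound 1 `COc1cc(-c2nnc(SCc3ccccc3[N+](=O)[O-])o2)ccc1O` gives 331000 nM. Compound 2 `COc1cc(-c2nnc(SCc3ccc(Cl)cc3)o2)ccc1O` gives 480000 nM, and compound 3 `COc1cc(-c2nnc(SCc3ccc(F)cc3)o2)ccc1O` gives 685000 nM, the highest of the three numbers; its step to compound 2 is within the scatter, while the gap to compound 1 is beyond it.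

Compound 4 `COc1cc(-c2nnc(SCc3ccccc3Cl)o2)ccc1O` has not yet been measured. Its change from compound 3 is 2-chlorophenyl in place of 4-fluorophenyl on a saturated chain carbon bound to a sulfur. Among the compounds with values here, the one measured step that bears on it is a 1.4-fold higher number from compound 2 to compound 3 (0.15 log units; within the scatter), showing that exchanging chloro for fluoro on the benzyl ring shifts the number only within the scatter. Within the data shown here, no measured pair shows what moving a substituent from one ring position to another does on its own; compound 1, whose substituent sits elsewhere on the ring, carries the lowest number of the three, but it also carries a different group, so that comparison is not clean.

On this basis compound 4 is expected to land somewhat below compound 3, at an estimated 450000 nM with a range from 250000 nM to 800000 nM, a step of a 1.5-fold lower number from compound 3 to compound 4 (0.18 log units; within the scatter) that is expected to stay within the scatter.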

Compound 4, half-maximal cytotoxic concentration: 564000 nM
For compound 4 the middle estimate is 1.3-fold (0.10 log units) below the measured one; the measured number falls inside the stated range.
By their numbers in this assay, from the lowest: compounds 1, 2, 4 and 3 (each within the scatter of the next, the first and the last beyond it).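

In this assay, within the data shown here, compound 4 gives the first clean reading of a move on the ring, 2-chlorophenyl in place of 4-chlorophenyl, and that move is a 1.2-fold higher number from compound 2 to compound 4 (0.07 log units; within the scatter), so these two placements of chloro are not told apart. Chloro in place of nitro on an aromatic carbon, a change the earlier compounds did not isolate, is a 1.7-fold higher number from compound 1 to compound 4 (0.23 log units; within the scatter), which leaves these two groups likewise not told apart. The remaining change, 2-chlorophenyl in place of 4-fluorophenyl, is a 1.2-fold lower number from compound 3 to compound 4 (0.08 log units; within the scatter), and no measurement shown here offers an explanation for any of these numbers.

The compounds shown leave open whether an amine or a carboxylic acid on the benzyl ring would shift the number beyond the scatter. They also leave open what a longer chain on the sulfur would do.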